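This account rests on a few compounds, and the source may have more. Where it says the series, first, only, none or still open, it means among the compounds named here.

In an assay for inhibition of Polyunsaturated fatty acid 5-lipoxygenase (Homo sapiens), tested at 1 uM (on this read-out higher numbers stand for a weaker effect at the one concentration tested and lower numbers for a stronger effect), compound 1 `CCOC(=O)CSc1nc(Cl)cc(Nc2ccc3ncccc3c2)n1` gives 86.3%, a weak effect at the single concentration. Compound 2 `CCCCC(Sc1nc(Cl)cc(Nc2ccc3ncccc3c2)n1)C(=O)O` is reported in this assay only as "not active" (no number reported), so compound 2 stands without a number of its own. Compound 3 `CCOC(=O)C(C)Sc1nc(Cl)cc(Nc2ccc3ncccc3c2)n1` carries the change (1-(ethoxycarbonyl)ethyl in place of 1-carboxypentyl on a sulfur). Compound 3 shares its ethoxycarbonyl group with compound 1, which in this assay gave 86.3%, so no step beyond the usual scatter from compound 2 is expected in this assay, with the effect staying weak. Compound 3 is therefore expected to give about 88% in this assay, most likely between 70% and 102%.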

Compound 3, a percentage reported as activity, at one concentration (the size of the read-out at that concentration, not a potency): "not active" (no number reported)
Compound 3 has no reported number here; there is nothing to compare the estimate with.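

In this assay compound 2 and compound 3 are both reported only as "not active", so no step can be read between them. No supporting evidence bears on this result. The compounds shown leave open whether 1-(ethoxycarbonyl)ethyl and 1-carboxypentyl on the sulfur differ in effect.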